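Shrinking the urea substituent: from aryl to methyl

This account rests on a few compounds, and the source may have more. Where it says the series, first, only, none or still open, it means among the compounds named here.

Two ureas sharing one core have been measured in an assay on isolated protein for inhibition of histamine H2 receptor (Cavia porcellus); a higher number here means weaker binding, a lower number tighter binding. Compound 1 `O=C(NCCCOc1cccc(CN2CCCCC2)c1)NCc1ccccc1` carries a benzyl group on the outer urea nitrogen, and in this assay compound 1 gives 347 nM. Compound 2 `O=C(NCCCOc1cccc(CN2CCCCC2)c1)Nc1ccc(C(F)(F)F)cc1` carries a 4-(trifluoromethyl)phenyl group in the same position, and in this assay compound 2 gives 1700 nM. Among the compounds with values here, the single step recorded so far, a 4.9-fold higher number from compound 1 to compound 2 (0.69 log units; beyond the scatter), shows that swapping benzyl for the aryl group costs binding. Within the data shown here, compound 2 therefore stands at the weaker end of the two numbers, with compound 1 as its only neighbour.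

Compound 3 `CNC(=O)NCCCOc1cccc(CN2CCCCC2)c1` is the next variation: methyl in place of 4-(trifluoromethyl)phenyl on an amide-type nitrogen. Among the measured compounds shown here, the only measured step concerns a change at this same nitrogen, but it exchanged one ring-bearing group for another, so it speaks only indirectly to replacing the aryl group with methyl. With no closer comparison available, the expected step is a 1.7-fold lower number from compound 2 to compound 3 (0.23 log units; within the scatter), a change of uncertain direction. Compound 3 is accordingly estimated at 1000 nM in this assay, with a plausible range from 300 nM to 4000 nM.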

Compound 3, dissociation constant: 155 nM
Estimate against measurement, compound 3: 6.5-fold (0.81 log units) above; measured number outside the range, below it.
By their numbers in this assay, from the lowest: compound 3; then compound 1; then compound 2.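

Within the data shown here, removing the ring altogether helps binding here rather than harming it: methyl in place of 4-(trifluoromethyl)phenyl on this amide-type nitrogen gives an 11-fold lower number from compound 2 to compound 3 (1.04 log units; beyond the scatter), by far the largest step so far. Compound 3 also beats the benzyl compound, with a 2.2-fold lower number from compound 1 to compound 3 (0.35 log units; beyond the scatter), so it binds most tightly of the three in this assay, and neither aromatic ring, whether held on a saturated chain carbon or placed directly on the nitrogen, is required for binding at this position. No measurement in hand explains why the three compounds fall in this order.

Hydrogen or an ethyl group on the same nitrogen would test whether binding keeps improving as the substituent gets smaller or is best near methyl, while an unsubstituted phenyl group would help separate the contribution of the ring from that of the trifluoromethyl group in compound 2. Going by these compounds, whether the same preference holds with a different amine in place of the piperidine, or with a longer or shorter chain in the shared core, also remains open.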